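A longer amine side chain on compound 3

This account rests on a few compounds, and the source may have more. Where it says the series, first, only, none or still open, it means among the compounds named here.

In a functional assay on LNCaP cells (Homo sapiens) for antiproliferative activity, read by WST assay, with a stated time of 3 days (a lower number here means a stronger inhibitor, a higher number a weaker inhibitor), compound 1 (`CCCOc1c(-c2cc(OC)c(OC)c(OC)c2)oc2ccccc2c1=O`) gives 5700 nM and compound 3 (`CCCN(CCC)CCCOc1c(-c2cc(OC)c(OC)c(OC)c2)oc2ccccc2c1=O`) gives 17900 nM as the higher of the two true numbers. Compound 2 (`CCCCCCCOc1c(-c2cc(OC)c(OC)c(OC)c2)oc2ccccc2c1=O`) reads > 50000 nM which is a limit, not a number. Compound 4 (`CCCCN(CCCC)CCCCOc1c(-c2cc(OC)c(OC)c(OC)c2)oc2ccccc2c1=O`) carries (dibutylamino)methyl in place of dipropylamino ((dibutylamino)methyl in place of dipropylamino on a saturated chain carbon, three bonds along the chain from an oxygen on an aromatic ring) on the same chain carbon. Extending that chain gave a 3.1-fold higher number from compound 1 to compound 3 (0.50 log units; beyond the scatter) and also an at least 8.7-fold higher number from compound 1 to compound 2 (0.94 log units; beyond the scatter) so growth has raised the number so far. Yet the amine chain gave an at least 2.7-fold lower number from compound 2 to compound 3 (0.44 log units; beyond the scatter) and this pulls the other way. The expected step is a 1.4-fold higher number from compound 3 to compound 4 (0.15 log units; within the scatter) and no change beyond the scatter is expected. Compound 4 is estimated at 25000 nM with an expected range from 7000 nM to 50000 nM in this assay.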

Compound 4, half-maximal inhibitory concentration: 7800 nM
Estimate against measurement, compound 4: 3.2-fold (0.51 log units) above, within the range that was stated.
By their numbers in this assay, from the lowest: compounds 1 and 4 (each within the scatter of the next); then compound 3. At a limit, above all of these: compound 2.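

In this assay, the longer amine chain gives a 2.3-fold lower number from compound 3 to compound 4 (0.36 log units; beyond the scatter), so adding length here does not always raise the number. With a 1.4-fold higher number from compound 1 to compound 4 (0.14 log units; within the scatter), a chain carrying dibutylamino sits level with the short chain of compound 1, which has no amine. The amine chain also gives an at least 6.4-fold lower number from compound 2 to compound 4 (0.80 log units; beyond the scatter), but that step rests on a limit for compound 2, not a true number: the limit of > 50000 nM in this assay, at which 1 of the 4 values shown sits.

The compounds shown leave open how a ring amine such as morpholine, or a carboxylic acid, would compare on this chain. On these data alone, a still longer amine chain also remains untested here.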